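A few compounds are considered here, and "the series" means these few. Any claim that something is new, unique, unknown or untested is made for them only; others in the source may bear on it.

In a functional assay on MCF7 cells (Homo sapiens) for cytotoxicity, read by MTT assay, with a stated time of 72 h (a lower number here means that less compound is tolerated, a higher number that more compound is tolerated), compound 1 `COc1ccc(CNc2nc([SeH])nc3ccccc23)cc1` gives only a limit, > 100000 nM. Compound 2 `Sc1nc(NCc2ccccc2)c2ccccc2n1` likewise gives only a limit in this assay, > 100000 nM. Compound 3 `COc1ccc(CNc2nc(SC)nc3ccccc23)cc1` also returns only a limit, > 100000 nM. All three therefore sit together at the limit of > 100000 nM in this assay, at which 3 of the 3 values shown sit, and none can be ordered against another. Within the data shown here, the single step between measured compounds, a step that the two limits leave unreadable from compound 1 to compound 3, remains unreadable between two limits. Compound 4 `COc1ccc(CNc2nc(S)nc3ccccc23)cc1` differs from compound 3 by hydrogen in place of methyl on a sulfur. Among the measured compounds shown here, no measured step bears on this change with a readable size, and every value shown is a limit, so nothing points to a number inside the range of this assay. Compound 4 is therefore expected to give 100000 nM, within 30000 nM to 300000 nM, most likely reported again only as a limit. The expected step of a number no higher from compound 3 to compound 4 (the limit leaves the size open) is thus none beyond the scatter.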

Compound 4, concentration lethal to 50% of the cells: 78400 nM
Estimate against measurement, compound 4: 1.3-fold (0.11 log units) above; the range from low to high includes it.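

In this assay, among these compounds, compound 4 is the only one of the four compounds that gives a number rather than a limit: the limit of > 100000 nM in this assay, at which 3 of the 4 values shown sit. Hydrogen in place of methyl on the sulfur gives an at least 1.2-fold lower number from compound 3 to compound 4 (0.10 log units; that floor lies within the scatter), methoxy in place of hydrogen on an aromatic carbon gives an at least 1.2-fold lower number from compound 2 to compound 4 (0.10 log units; that floor lies within the scatter), and one sulfur atom in place of one selenium atom gives an at least 1.2-fold lower number from compound 1 to compound 4 (0.10 log units; that floor lies within the scatter). Each of these is only a floor, so none of the three changes is shown to reach beyond the scatter.

As far as these compounds go, the true size of all three steps remains open. So does what an amine or a carboxylic acid in place of the sulfanyl, or a longer chain on the sulfur, would do in this assay.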